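Phenyl in Place of Ethynyl on a Pyridyl Ether

The source may hold more compounds than are shown below. What is called first, only, known or untested is meant among the compounds shown, and "the series" means these compounds.

Measured in an assay on a protein complex for binding affinity to Neuronal acetylcholine receptor; alpha4/beta2 (Rattus norvegicus); on this read-out higher numbers stand for weaker inhibition and lower numbers for stronger inhibition:
Compound 1 `c1cncc(OC2CNC2)c1` — a limit only, > 10000 nM
Compound 2 `C#Cc1cncc(O[C@@H]2CCNC2)c1` — 62 nM
Compound 3 `C#Cc1cc(O[C@@H]2CCNC2)cnc1Cl` — 46 nM

Compound 1 reaches only the limit of this assay, (the limit of > 10000 nM in this assay, at which 1 of the 3 values shown sits), and yields no number. Compound 2 therefore sits among just two numbers; its nearest neighbour is compound 3, reached by a 1.3-fold lower number from compound 2 to compound 3 (0.13 log units; within the scatter), a change of chloro in place of hydrogen on an aromatic carbon that stays within the scatter.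

Compound 4 `c1ccc(-c2cncc(O[C@@H]3CCNC3)c2)cc1` differs from compound 2 in one place: phenyl in place of ethynyl on an aromatic carbon. Within the data shown here, no measured step touches this group. Among the measured compounds shown here, the single measured step, a 1.3-fold lower number from compound 2 to compound 3 (0.13 log units; within the scatter), concerns another position and is itself within the scatter, so it gives no scale for the present change. The expectation rests only on the absence of a precedent and on compound 2 as the starting point, 62 nM.

Compound 4 is estimated at 400 nM in this assay, between 60 nM and 3000 nM. That estimate is expected to mean a 6.5-fold higher number from compound 2 to compound 4 (0.81 log units; beyond the scatter), a step that may well exceed the scatter but is poorly bounded on either side.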

Compound 4, half-maximal inhibitory concentration: 1820 nM
Beside the measured number, compound 4's estimate is 4.6-fold (0.66 log units) below it, within the range that was stated.
By their numbers in this assay, from the lowest: compounds 3 and 2 (each within the scatter of the next); then compound 4. At a limit, above all of these: compound 1.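

In this assay, the aromatic carbon two atoms from the ring nitrogen proves sensitive to what it carries: phenyl in place of ethynyl there gives a 29-fold higher number from compound 2 to compound 4 (1.47 log units; beyond the scatter). This is the only step shown that lies beyond the scatter, and it gives this position a scale that the chloro change at another position, a 1.3-fold lower number from compound 2 to compound 3 (0.13 log units; within the scatter), could not provide. Nothing given here bears on the cause of this step.

The compounds shown leave open whether groups with other atom counts or atoms at this place, such as methyl, a nitrile or an amine, would stay near compound 2 or follow compound 4. They also leave open whether a pyridyl ring in place of phenyl would give a different number.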